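Aryl variation on the carbonyl carbon: cytotoxicity notes

A few compounds are considered here, and "the series" means these few. Any claim that something is new, unique, unknown or untested is made for them only; others in the source may bear on it.

Going by the values given here, compound 3 `Cc1cc(C(=O)/C=C/c2ccc(N3CCCCC3)cc2)c(C)s1` gives 38200 nM in an ADME assay on PBMC cells (Homo sapiens) for cytotoxicity, with a stated time of 5 days (on this read-out lower numbers stand for stronger inhibition and higher numbers for weaker inhibition), the only actual number among the three values shown. Compound 1 `O=C(/C=C/c1ccc(N2CCCCC2)cc1)c1cccs1` sits at > 100000 nM in this assay, which is a limit. Compound 2 `O=C(/C=C/c1ccc(N2CCCCC2)cc1)c1ccsc1` likewise sits at > 100000 nM, again a limit. The two steps into compound 3 read an at least 2.6-fold lower number from compound 1 to compound 3 (0.41 log units; beyond the scatter) and an at least 2.6-fold lower number from compound 2 to compound 3 (0.41 log units; beyond the scatter), while a step that the two limits leave unreadable from compound 1 to compound 2. Compound 4 `O=C(/C=C/c1ccc(N2CCCCC2)cc1)c1ccc(I)s1` carries 5-iodothiophen-2-yl in place of 2,5-dimethylthiophen-3-yl on a carbonyl carbon. Among the compounds with values here, no measured step involves an iodine on the ring; the two readable steps only show that the methyl groups take the number from the limit to a measurable value, and compound 4 lacks them. The change is expected to undo at least part of that gain, with a fair chance that only a limit is recorded, given (the limit of > 100000 nM in this assay, at which 2 of the 3 values shown sit). Compound 4 is therefore estimated at 70000 nM, within 25000 nM to 200000 nM. This amounts to an expected step of a 1.8-fold higher number from compound 3 to compound 4 (0.26 log units; within the scatter).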

Compound 4, half-maximal inhibitory concentration: > 100000 nM
Compound 4 ended at the assay's limit (the forecaster's own chance of this, stated with the estimate: 45%); at least 1.4-fold (0.15 log units) between middle value and limit.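

Replacing 2,5-dimethylthiophen-3-yl with 5-iodothiophen-2-yl on the carbonyl carbon gives an at least 2.6-fold higher number from compound 3 to compound 4 (0.41 log units; beyond the scatter) in this assay, so a ring substituent alone does not secure a measurable number at this position. Among the compounds shown, only the 2,5-dimethylthiophen-3-yl group of compound 3 leaves the limit, and the iodine of compound 4 does not, while the steps from compound 1 and compound 2 to compound 4 cannot be read, as both ends are limits. The position now reads mostly as a ceiling: the limit of > 100000 nM in this assay, at which 3 of the 4 values shown sit.

From the compounds shown here alone, the step into compound 4 changes both the ring substituents and the point of attachment, so the share of each stays open. Also open, going by these compounds, is whether a single methyl, a chloro group or a carboxylic acid on the thiophene would give a measurable number.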